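The source may report more compounds than this note shows. Statements on the series, on what has been measured and on what is new or still open speak of the compounds shown alone.

Measured compounds:
- compound 2, `CCCOC(=O)Nc1ccc([Se]C#N)cc1`: 28400 nM in a functional assay on HT-29 cells (Homo sapiens) for cytotoxicity, read by MTT assay, with a stated time of 72 h; on this read-out lower numbers stand for stronger inhibition of growth and higher numbers for weaker inhibition of growth
- compound 1, `CC(C)COC(=O)Nc1ccc([Se][Se]c2ccc(NC(=O)OCC(C)C)cc2)cc1`: 19900 nM in this assay
- compound 3, `CCOC(=O)Nc1ccc([Se][Se]c2ccc(NC(=O)OCC)cc2)cc1`: 26000 nM in this assay

The three numbers sit close together. Compound 2 is separated from compound 3 and from compound 1 by less than the usual scatter of repeated measurements, so no real difference among the three can be claimed from these values.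

Compound 4, `C=CCOC(=O)Nc1ccc([Se]C#N)cc1`, has not yet been measured in this assay. It differs from compound 2 in one spot: vinyl in place of ethyl on a saturated chain carbon bound to an oxygen next to a carbonyl group. Among the measured compounds shown here, the change is small and no measured pair shows a comparable step, so a step no larger than the scatter, in either direction, is expected. For compound 4 the estimate in this assay is therefore 28000 nM, with a likely range from 14000 nM to 56000 nM, meaning an expected step of a 1.0-fold lower number from compound 2 to compound 4 (0.01 log units; within the scatter).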

Compound 4, concentration for 50% growth inhibition: 24500 nM
Estimate against measurement, compound 4: 1.1-fold (0.06 log units) above; the measured number falls inside the stated range.
By their numbers in this assay, from the lowest: compounds 1, 4, 3 and 2 (each within the scatter of the next).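

In this assay, among the compounds shown here, vinyl in place of ethyl on a saturated chain carbon bound to an oxygen next to a carbonyl group gives a 1.2-fold lower number from compound 2 to compound 4 (0.06 log units; within the scatter), the first one-place comparison in this set. At this place, then, bringing in a double bond outside the aromatic ring leaves the number within the scatter. Nothing measured here bears on the reason for this result.

From the compounds shown here alone, whether a longer chain such as hexyl, or a benzyl group, would move the number beyond the scatter stays open. So does the effect of the same change on the core of compound 1.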